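Series notes: para-substituent swap on the benzylamine arm

This account rests on a few compounds, and the source may have more. Where it says the series, first, only, none or still open, it means among the compounds named here.

Compound 2 `Nc1cc(N)c2nc(-c3ccccc3)c(NCc3ccc(F)cc3)nc2c1` gives 53700 nM in a functional assay on SK-OV-3 cells (Homo sapiens) for inhibition, read by sulforhodamine B assay, with a stated time of 48 h; a higher number here means that more compound is tolerated, a lower number that less compound is tolerated; its only companion, compound 1 `Nc1cc(N)c2nc(-c3ccccc3)c(NCc3ccc(Cl)c(Cl)c3)nc2c1`, gives 69200 nM, and the step of a 1.3-fold lower number from compound 1 to compound 2 (0.11 log units; within the scatter) separates them. Compound 3 `COc1ccc(CNc2nc3cc(N)cc(N)c3nc2-c2ccccc2)cc1` carries methoxy in place of fluoro on an aromatic carbon. Within the data shown here, no measured step touches a methoxy group; the one step available, from compound 1 to compound 2, exchanged halogen patterns on the same ring without moving beyond the scatter, so compound 3 is expected to show a step of a 1.0-fold higher number from compound 2 to compound 3 (0.01 log units; within the scatter), no real movement in this assay. Compound 3 is therefore estimated at 55000 nM, with a range from 25000 nM to 120000 nM.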

Compound 3, concentration lethal to 50% of the cells: < 100000 nM
Compound 3 was reported as a limit; the forecaster's own chance of this, stated with the estimate: 15%; the middle value is on the limit's open side.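

In this assay, among these compounds, compound 3 is reported only as a limit, < 100000 nM, so no step from compound 1 or compound 2 to compound 3 can be read. On these data alone, whether 4-methoxybenzyl differs from 4-fluorobenzyl on the shared core stays open.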